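Working notes: from compound 1 to compound 4

A few compounds are considered here, and "the series" means these few. Any claim that something is new, unique, unknown or untested is made for them only; others in the source may bear on it.

Compound 1 `CC(C)C(c1ccc(-c2ccc3cccc(F)c3c2)[nH]c1=O)N1CCCCS1(=O)=O` is the reference of this short set. In an ADME assay on microsomes from liver (Rattus norvegicus) for metabolic stability (a higher number here means that the compound lasts longer, a lower number that the compound disappears faster), compound 1 gives 0.07 h, the lowest of the three numbers, though its neighbours lie within the scatter. Compound 2 `CC(C)C(c1ccc(-c2ccc3cccc(F)c3c2)[nH]c1=O)N1CCCCC1=O` gives 0.102 h in this assay, and compound 3 `CC(C)C(c1cnc(N)s1)c1ccc(-c2ccc3cccc(F)c3c2)[nH]c1=O` gives 0.0983 h. The two steps from compound 1 were a 1.5-fold higher number from compound 1 to compound 2 (0.16 log units; within the scatter) and a 1.4-fold higher number from compound 1 to compound 3 (0.15 log units; within the scatter); the step of a 1.0-fold lower number from compound 2 to compound 3 (0.02 log units; within the scatter) was likewise flat.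

Compound 4 `CC(C)C(Cc1nnn[nH]1)c1ccc(-c2ccc3cccc(F)c3c2)[nH]c1=O` changes the same place: a group of 6 heavy atoms (2 carbon, 4 nitrogen; one five-membered aromatic ring with 4 hetero atoms) in place of a group of 8 heavy atoms (4 carbon, 1 nitrogen, 2 oxygen, 1 sulfur; one six-membered non-aromatic ring with 2 hetero atoms), on a saturated chain carbon bound to an aromatic carbon and a saturated chain carbon. Both earlier replacements at that carbon left the half-life unchanged beyond the scatter, so no step beyond the scatter is expected here either, at most a slight rise as seen in a 1.4-fold higher number from compound 1 to compound 3 (0.15 log units; within the scatter). Compound 4 is thus expected to give 0.09 h, range 0.04 h to 0.2 h, which means an expected step of a 1.3-fold higher number from compound 1 to compound 4 (0.11 log units; within the scatter).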

Compound 4, half-life: 2.08 h
Beside the measured number, compound 4's estimate is 23-fold (1.36 log units) below it; the whole stated range lies below it.
By their numbers in this assay, from the lowest: compounds 1, 3 and 2 (each within the scatter of the next); then compound 4.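

At the saturated chain carbon bound to an aromatic carbon and a saturated chain carbon, the half-life in this assay can respond strongly to the group carried: (1H-tetrazol-5-yl)methyl gives a 30-fold higher number from compound 1 to compound 4 (1.47 log units; beyond the scatter), a 21-fold higher number from compound 3 to compound 4 (1.33 log units; beyond the scatter) and a 20-fold higher number from compound 2 to compound 4 (1.31 log units; beyond the scatter). Among the compounds shown, the place therefore separates this group from three others that stay within the scatter of one another. Nothing available accounts for the difference.

Still open, on these data alone, is whether the step belongs to the tetrazolyl ring or to the methyl part of the group. A carboxylic acid at the same place would test how specific the step is to that ring.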